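Trading acetyl for trifluoromethyl: an antiproliferative estimate

This account rests on a few compounds, and the source may have more. Where it says the series, first, only, none or still open, it means among the compounds named here.

Measured so far in a functional assay on A549 cells (Homo sapiens) for antiproliferative activity, read by MTT assay, with a stated time of 72 h; on this read-out higher numbers stand for weaker inhibition and lower numbers for stronger inhibition
compound 1 `COc1cc(-n2cnc3ccc(-c4ccc(C(C)=O)cc4)cc32)cc(OC)c1OC` gives 2510 nM
compound 2 `COc1ccc(-c2ccc3ncn(-c4cc(OC)c(OC)c(OC)c4)c3c2)cc1F` gives 1430 nM
compound 3 `COc1cc(-n2cnc3ccc(-c4ccccc4)cc32)cc(OC)c1OC` gives 3060 nM

Compound 1 stands in the middle of these three numbers, and its steps to the other two lie within the scatter. Compound 4 `COc1cc(-n2cnc3ccc(-c4ccc(C(F)(F)F)cc4)cc32)cc(OC)c1OC` differs from it by one change, trifluoromethyl in place of acetyl on an aromatic carbon. Going by the values given here, three measured steps bear on this. Putting hydrogen in place of acetyl gave a 1.2-fold higher number from compound 1 to compound 3 (0.09 log units; within the scatter) and exchanging 4-acetylphenyl for 3-fluoro-4-methoxyphenyl gave a 1.8-fold lower number from compound 1 to compound 2 (0.24 log units; within the scatter) in the same series. Only a 2.1-fold higher number from compound 2 to compound 3 (0.33 log units; beyond the scatter) passes the scatter, and it remains modest. None of these steps tests trifluoromethyl itself, so the evidence is indirect. Even so, this assay is expected to show no step beyond the scatter, in either direction. The estimate amounts to an expected (a 1.1-fold lower number from compound 1 to compound 4 (0.06 log units; within the scatter)). Compound 4 is estimated at 2200 nM (expected range 1100 nM to 4500 nM).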

Compound 4, half-maximal inhibitory concentration: 3390 nM
Estimate against measurement, compound 4: 1.5-fold (0.19 log units) below; measured number inside the range.
By their numbers in this assay, from the lowest: compounds 2, 1, 3 and 4 (each within the scatter of the next, the first and the last beyond it).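

At this place on the aromatic ring, this assay does not separate trifluoromethyl from acetyl (a 1.4-fold higher number from compound 1 to compound 4 (0.13 log units; within the scatter)) or from hydrogen (a 1.1-fold higher number from compound 3 to compound 4 (0.04 log units; within the scatter)), so all three groups read alike within the scatter. Going by these compounds alone, the one new step that passes the scatter (a 2.4-fold higher number from compound 2 to compound 4 (0.37 log units; beyond the scatter)) stays modest, and because it exchanges 3-fluoro-4-methoxyphenyl for 4-(trifluoromethyl)phenyl as a whole, it does not isolate a single substituent. Nothing available here explains why these groups read alike.

The compounds shown leave open whether an amine or a carboxylic acid at this place would move the number beyond the scatter. They also leave open whether a methoxy group alone, without the fluorine, would match the number of compound 2.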